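Sulfonyl aryl swap in the piperidinyl series

The compounds below may be only part of what the source reports. "The series", "measured", "known", "first", "only" and "open" are said of these compounds alone.

Compound 2 `CC1CCN(c2c(S(=O)(=O)c3ccc(F)c(F)c3)cnc3cc(F)ccc23)CC1` gives 94% in an assay on isolated protein for displacement of a labelled ligand from metabotropic glutamate receptor 5 (Homo sapiens), with a stated time of 60 min, tested at 1 uM (on this read-out lower numbers stand for less inhibition and higher numbers for more inhibition at the one concentration tested (going by the name of the read-out)), which is the highest of the three numbers in hand; its nearest neighbour is compound 3 `CC1CCN(c2c(S(=O)(=O)c3ccc(F)c(F)c3)cnc3cc(Cl)ccc23)CC1` with 90%, and the furthest is compound 1 `CC1CCN(c2c(S(=O)(=O)c3ccc(Cl)c(Cl)c3)cnc3ccc(Cl)cc23)CC1` with 86%, both gaps lying within the scatter. Going by the values given here, the only single-site step among the measured compounds is a number 4 percentage points lower from compound 2 to compound 3 (within the scatter), so nothing here separates the compounds beyond the noise.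

Compound 4 `Cc1ccc(S(=O)(=O)c2cnc3cc(F)ccc3c2N2CCC(C)CC2)cc1Cl` differs from compound 2 by 3-chloro-4-methylphenyl in place of 3,4-difluorophenyl on a sulfonyl sulfur. Among the compounds with values here, no measured step changes the sulfonyl aryl group alone; compound 1 carries a 3,4-dichlorophenyl on the sulfonyl sulfur together with a different core halogen, and its value against that of compound 2 and of compound 3 again falls within the scatter. Chlorine on that aryl ring therefore goes with a number level with the others as far as these numbers tell, while a methyl at the same ring has no precedent in the set. The expectation for compound 4 is accordingly a step of a number 6 percentage points lower from compound 2 to compound 4 (within the scatter), that is, no change beyond the scatter, with a slight lean downward because compound 1 sits at 86%. Compound 4 is estimated at 88%, within 74% to 97%.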

Compound 4, a percentage reported as inhibition, at one concentration (the size of the read-out at that concentration, not a potency): 93%
For compound 4 the middle estimate is 5 percentage points below the measured one; measured number inside the range.
By their numbers in this assay, from the lowest: compounds 1, 3, 4 and 2 (each within the scatter of the next).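

The sulfonyl aryl group now has a step of its own, with the rest of the structure held fixed: in this assay, 3-chloro-4-methylphenyl in place of 3,4-difluorophenyl on a sulfonyl sulfur gives a number 1 percentage points lower from compound 2 to compound 4 (within the scatter). Compound 1 could only hint at this, as its aryl change came together with a different core halogen, whereas this pair shows directly that replacing both fluoro substituents with a chloro and a methyl leaves the read-out within the scatter. No measurement available here bears on why the two aryl groups read alike.

All four compounds are read at a single concentration and no listed step lies beyond the scatter, so how far they differ in potency remains open, and no ranking can be drawn from these numbers. Also open, on these data alone, is whether this position stays level with groups of a different kind on the sulfonyl sulfur, such as a phenyl ring carrying a carboxylic acid or an amine, or a longer alkyl chain in place of the aryl ring.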